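The source may hold more compounds than are shown below. What is called first, only, known or untested is meant among the compounds shown, and "the series" means these compounds.

Of the compounds shown here, three have been measured in an assay on cells for inhibition of sodium channel protein type 3 subunit alpha (Homo sapiens), read by electrophysiology; a lower number here means a stronger inhibitor, a higher number a weaker inhibitor. Compound 1 `O=C(NCc1ccc(C(F)(F)F)cc1)c1ccc(S(=O)(=O)Nc2nccs2)cc1` gives 147 nM. Compound 2 `O=S(=O)(Nc1nccs1)c1ccc(-c2nnc(Cc3ccc(C(F)(F)F)cc3)[nH]2)cc1` gives 124 nM. Compound 3 `O=C(NCc1ccc(OC(F)(F)F)c(Cl)c1)c1ccc(S(=O)(=O)Nc2nccs2)c(F)c1` gives 11 nM, the lowest number of the three; its gaps to compound 2 and to compound 1 both lie beyond the usual scatter, so compound 3 is the strongest inhibitor seen so far.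

Compound 4 `O=C(NCc1ccc(OC(F)(F)F)c(Cl)c1)c1ccc(S(=O)(=O)Nc2ncccn2)c(F)c1` differs from compound 3 in one place: pyrimidin-2-yl in place of 1,3-thiazol-2-yl on a sulfonamide nitrogen. Within the data shown here, no pair of measured compounds shows this particular change, so there is no measured step to lean on; what follows rests only on the closeness of the two groups, each a small aromatic ring with two hetero atoms and two hydrogen-bond acceptors, on the same sulfonamide nitrogen.

The expectation is a modest loss of potency, a step from compound 3 to compound 4 of about a 2.3-fold higher number from compound 3 to compound 4 (0.36 log units; beyond the scatter), roughly at the edge of the scatter. Compound 4 is thus estimated to give 25 nM in this assay, within a range from 7 nM to 90 nM.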

Compound 4, half-maximal inhibitory concentration: 374 nM
Estimate against measurement, compound 4: 15-fold (1.17 log units) below; measured number outside the range, above it.
By their numbers in this assay, from the lowest: compound 3; then compounds 2 and 1 (each within the scatter of the next); then compound 4.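

Replacing 1,3-thiazol-2-yl with pyrimidin-2-yl on the sulfonamide nitrogen gives a 34-fold higher number from compound 3 to compound 4 (1.53 log units; beyond the scatter) in this assay, so this position, which carries the same group in all three earlier compounds, proves highly sensitive to which ring sits there. The two rings match in hetero atoms and hydrogen-bond acceptors, yet they differ in ring size and are clearly not interchangeable here, so those matching counts alone do not preserve the potency of compound 3. Nothing measured here explains why the two rings differ so sharply.

A pyridin-2-yl or 1,3-oxazol-2-yl group on the same nitrogen would help show whether the loss follows ring size or the placement of the ring nitrogens. On these data alone, it also remains open whether pyrimidin-2-yl would cost as much on the core of compound 1.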